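This account rests on a few compounds, and the source may have more. Where it says the series, first, only, none or still open, it means among the compounds named here.

Measured in an in vitro ADME assay on microsomes from liver (Homo sapiens) for metabolic stability; a lower number here means slower removal, a higher number faster removal of the compound:
- compound 1 `Fc1ccccc1Cc1nc(-c2nc(C(F)F)n[nH]2)n2ccccc12`: 62 mL.min-1.g-1
- compound 2 `Cc1ncc(Cc2nc(-c3nc(C(F)(F)F)n[nH]3)n3ccccc23)cn1`: < 8 mL.min-1.g-1
- compound 3 `Fc1ccccc1Cc1nc(-c2nc(Cc3ccccc3)n[nH]2)n2ccccc12`: "not determined" (no result reported)

Compound 2 stands at the limit of < 8 mL.min-1.g-1 in this assay, at which 1 of the 3 values shown sits. Its entry of < 8 mL.min-1.g-1 is a limit and not a number.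

Compound 4 `Cc1ncc(Cc2nc(-c3nc(C(F)(F)F)n[nH]3)n3cccc(F)c23)cn1` differs from compound 2 on the shared core, with fluoro in place of hydrogen on an aromatic carbon. For the measured compounds named here, no measured pair shows this change, so nothing points to a direction. The expected step of a number no lower from compound 2 to compound 4 (the limit leaves the size open) in this assay is small and is not expected to go beyond the scatter.

In this assay, compound 4 is estimated at 8 mL.min-1.g-1, with an expected range of 4 mL.min-1.g-1 to 16 mL.min-1.g-1.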

Compound 4, intrinsic clearance in microsomes: < 8 mL.min-1.g-1
Compound 4 ended at the assay's limit; the forecaster's own chance of this, stated with the estimate: 55%; the middle value lies on the limit itself.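

No step from compound 2 to compound 4 can be read, because both entries are limits and not numbers: the limit of < 8 mL.min-1.g-1 in this assay, at which 2 of the 4 values shown sit.

The compounds shown leave open whether fluoro in place of hydrogen on an aromatic carbon changes intrinsic clearance at all.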